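Series notes: replacing the pendant aryl with bromo

This account rests on a few compounds, and the source may have more. Where it says the series, first, only, none or still open, it means among the compounds named here.

Half-lives in an ADME assay on microsomes from liver (Rattus norvegicus) for metabolic stability, read by HPLC, using NADPH, tested at 1 mM (on this read-out lower numbers stand for a shorter-lived compound and higher numbers for a longer-lived compound), so far:
compound 1 `COc1cc(NC(C)CCCNC(=O)C2CCC3(CC2)OOC2(OO3)C3CC4CC(C3)CC2C4)c2ncccc2c1-c1ccccc1`: 0.7 h
compound 2 `COc1cc(NC(C)CCCNC(=O)C2CCC3(CC2)OOC2(OO3)C3CC4CC(C3)CC2C4)c2ncccc2c1-c1ccc(Cl)cc1`: 2.15 h
compound 3 `COc1cc(NC(C)CCCNC(=O)C2CCC3(CC2)OOC2(OO3)C3CC4CC(C3)CC2C4)c2ncccc2c1-c1ccc(C(F)(F)F)cc1`: 1.67 h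

Compound 2 gives the highest number of the three, though its gap to compound 3 is within the scatter; only its step from compound 1 is beyond it, a 3.1-fold higher number from compound 1 to compound 2 (0.49 log units; beyond the scatter). Compound 4 `COc1cc(NC(C)CCCNC(=O)C2CCC3(CC2)OOC2(OO3)C3CC4CC(C3)CC2C4)c2ncccc2c1Br` differs from compound 2 by bromo in place of 4-chlorophenyl on an aromatic carbon. Among the compounds with values here, no measured step removes the aryl group; the steps that bear on it are a 3.1-fold higher number from compound 1 to compound 2 (0.49 log units; beyond the scatter) and a 2.4-fold higher number from compound 1 to compound 3 (0.38 log units; beyond the scatter), both showing a substituted aryl outlasting the bare one. With the aryl gone, a number nearer compound 1 than compound 2 is expected, so the step of a 2.2-fold lower number from compound 2 to compound 4 (0.33 log units; beyond the scatter) is estimated downward. Compound 4 is expected at 1 h, within 0.4 h to 2.5 h.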

Compound 4, half-life: 0.233 h
Beside the measured number, compound 4's estimate is 4.3-fold (0.63 log units) above it; the measured number lies below the stated range.
By their numbers in this assay, from the lowest: compound 4; then compound 1; then compounds 3 and 2 (each within the scatter of the next).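

In this assay, bromo in place of the pendant aryl gives the lowest number of the series, whichever aryl it replaces (a 9.2-fold lower number from compound 2 to compound 4 (0.97 log units; beyond the scatter); a 7.2-fold lower number from compound 3 to compound 4 (0.86 log units; beyond the scatter); a 3.0-fold lower number from compound 1 to compound 4 (0.48 log units; beyond the scatter)). The earlier compounds shown here all carried an aryl here and showed only that substituents on it raise the number; the last step adds that even the bare phenyl outlasts bromo. Nothing available accounts for this drop. On these data alone, whether the half-life depends on an aryl ring as such stays open. A pyridine ring or a dimethylamino group at this position would test that.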